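Biaryl Acids at Bombesin Receptor Subtype-3: A Nitrile Variant

The source may hold more compounds than are shown below. What is called first, only, known or untested is meant among the compounds shown, and "the series" means these compounds.

Two measured compounds share a biaryl acid attached to an imidazole. Compound 1 `CCCCc1cnc(C(CCC)Cc2ccc(-c3ccccc3C(=O)O)cc2)[nH]1` gives 165 nM in an in vitro functional assay on cells for agonist activity at Bombesin receptor subtype-3 (Mus musculus), read by luminescence and calcium flux; a higher number here means that more compound is needed for the effect, a lower number that less compound is needed. Compound 2 `O=C(O)c1ccccc1-c1ccc(CCc2ncc(Cc3ccccc3Cl)[nH]2)cc1` gives 22 nM in this assay, the lower of the two numbers; the gap from compound 1 down to compound 2 lies beyond the usual scatter.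

Compound 3 `N#Cc1cccc(Cc2cnc(CCc3ccc(-c4ccccc4C(=O)O)cc3)[nH]2)c1` has not yet been measured. It differs from compound 2 by 3-cyanophenyl in place of 2-chlorophenyl on a saturated chain carbon bound to an aromatic carbon. Within the data shown here, no measured pair shows this change, so its effect is unknown from the data at hand.

With nothing in the measured pairs to anchor it, the step from compound 2 to compound 3 is expected to be modest and upward, though a result within the scatter would not surprise; the expected step is a 2.3-fold higher number from compound 2 to compound 3 (0.36 log units; beyond the scatter). In this assay compound 3 is expected to give about 50 nM, with a likely range from 15 nM to 200 nM.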

Compound 3, half-maximal effective concentration: 20 nM
For compound 3 the middle estimate is 2.5-fold (0.40 log units) above the measured one; the range from low to high includes it.
By their numbers in this assay, from the lowest: compounds 3 and 2 (each within the scatter of the next); then compound 1.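

In this assay, among these compounds, the exchange of 2-chlorophenyl for 3-cyanophenyl gives a 1.1-fold lower number from compound 2 to compound 3 (0.04 log units; within the scatter), the first reading of any change at this place, on a saturated chain carbon bound to an aromatic carbon. The two groups cannot be told apart here, so this place accepts a chlorine-bearing ring and a nitrile-bearing ring alike, even though only the 3-cyanophenyl group counts a hydrogen-bond acceptor. Nothing at hand accounts for this equivalence.

The group and its place on the ring change together in this pair, so the compounds shown cannot separate the two contributions. As far as these compounds go, how 3-chlorophenyl, 2-cyanophenyl or an unsubstituted phenyl would read at this place stays open, as does whether an amine on the ring would be accepted as well.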